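This account rests on a few compounds, and the source may have more. Where it says the series, first, only, none or still open, it means among the compounds named here.

Among the measured compounds shown here, compound 2 `COc1cc(-c2cc(/C=C/C(=O)c3ccc(N)cc3)[nH]n2)cc(OC)c1OC` is the only compound here with a number: in a functional assay on SK-MEL-2 cells (Homo sapiens) for inhibition, read by sulforhodamine B assay, with a stated time of 48 h (on this read-out lower numbers stand for stronger inhibition of growth and higher numbers for weaker inhibition of growth), compound 2 gives 2850 nM. Compound 1 `COc1ccc(-c2cc(/C=C/C(=O)c3ccc(N)cc3)[nH]n2)cc1` has no result in this assay, where compound 1 gives "not determined" (no result reported). Compound 3 `COc1cc(-c2cc(/C=C/C(=O)c3ccc(Cl)c(Cl)c3)[nH]n2)cc(OC)c1OC` differs from compound 2 in one place only: 3,4-dichlorophenyl in place of 4-aminophenyl on a carbonyl carbon. For the measured compounds named here, no pair of measured compounds shows this change, so its size is unknown from the data. The step from compound 2 to compound 3 is expected to stay within the scatter or to bring a small gain, which is what a 1.4-fold lower number from compound 2 to compound 3 (0.15 log units; within the scatter) means. Compound 3 is therefore estimated at 2000 nM, with a range from 500 nM to 8000 nM.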

Compound 3, concentration for 50% growth inhibition: 13900 nM
Estimate against measurement, compound 3: 7.0-fold (0.84 log units) below; the measured number lies above the stated range.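

In this assay, the group on the carbonyl carbon clearly matters: 3,4-dichlorophenyl in place of 4-aminophenyl brings a 4.9-fold higher number from compound 2 to compound 3 (0.69 log units; beyond the scatter), which means weaker inhibition of growth. Of these two groups, 4-aminophenyl is therefore the better one at this position. Nothing measured here says why the two groups differ. On these data alone, it remains open whether the amine or the two chlorines drive the gap, and a plain phenyl or a 4-hydroxyphenyl at this position could help separate them. Also open, as far as these compounds go, is whether the same change acts alike on the core of compound 1, which has no result in this assay.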